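This account rests on a few compounds, and the source may have more. Where it says the series, first, only, none or still open, it means among the compounds named here.

Compound 2 `O=C(O)CCCOc1ccc(OCc2ccc3ccccc3n2)cc1` carries a carboxy group at the end of a chain, and in a functional assay (lung) for inhibition, with Cavia porcellus as the target (on this read-out lower numbers stand for stronger inhibition and higher numbers for weaker inhibition), compound 2 gives 800 nM. Compound 1 `c1ccc2nc(COc3ccc(OCCCc4nnn[nH]4)cc3)ccc2c1` differs from it by 1H-tetrazol-5-yl in place of carboxy on a saturated chain carbon, three bonds along the chain from an oxygen on an aromatic ring. In this assay compound 1 gives 250 nM. That change made a step of a 3.2-fold lower number from compound 2 to compound 1 (0.51 log units; beyond the scatter). Compound 3 `O=C(O)CC1(CCc2ccc(OCc3ccc4ccccc4n3)cc2)CCCC1` is built on a different core; the difference between the two cores is not broken down here. In this assay compound 3 gives 60 nM, the lowest of the three numbers. Compound 4 `c1ccc2nc(COc3ccc(CCC4(Cc5nnn[nH]5)CCCC4)cc3)ccc2c1` differs from compound 3 by 1H-tetrazol-5-yl in place of carboxy on a saturated chain carbon bound to a saturated ring carbon. This is the same kind of change as that made between compound 2 and compound 1, though the place differs: there the group sat on a saturated chain carbon, three bonds along the chain from an oxygen on an aromatic ring, here on a saturated chain carbon bound to a saturated ring carbon. Compound 4 is expected to improve on compound 3 by about a 2.4-fold lower number from compound 3 to compound 4 (0.38 log units; beyond the scatter), resting on one earlier example only, a 3.2-fold lower number from compound 2 to compound 1 (0.51 log units; beyond the scatter). Compound 4 is therefore estimated at 25 nM, with a range from 8 nM to 80 nM.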

Compound 4, half-maximal inhibitory concentration: 37 nM
Compound 4: middle estimate off by 1.5-fold (0.17 log units), on the low side; the range from low to high includes it.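

In this assay, 1H-tetrazol-5-yl in place of carboxy gives a 1.6-fold lower number from compound 3 to compound 4 (0.21 log units; within the scatter) and so shows no clear change on this core. The swap does not behave measurably differently on the two cores: the same change on two cores in this assay, a 3.2-fold lower number (0.51 log units; beyond the scatter) from compound 2 to compound 1 and a 1.6-fold lower number (0.21 log units; within the scatter) from compound 3 to compound 4, 2.0-fold (0.30 log units) apart, within the scatter of two such steps. This means the tetrazole can stand in for the carboxy on both cores without a clear loss, but two pairs cannot show that the step is truly the same size on each core, or that it is a real gain on the core of compound 3.

The compounds shown leave open how an amide in the same place would read, and whether a longer chain would alter the result. A third core would also be needed to test how far the swap carries.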